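The source may hold more compounds than are shown below. What is called first, only, known or untested is meant among the compounds shown, and "the series" means these compounds.

Measured so far:
compound 1 `c1ccc(-c2ccc(Cn3cncc3CNc3ccc(-c4ccccc4)c(-c4ccccc4)c3)cc2)cc1` in a toxicity assay on NIH3T3 cells (Mus musculus) for cytotoxicity, read by resazurin assay; a lower number here means that less compound is needed, a higher number that more compound is needed for the effect: > 10000 nM
compound 2 `c1ccc(-c2ccc(Cn3cncc3CNc3ccc(-c4ccccc4)cc3)cc2)cc1` in this assay: > 10000 nM

In this assay compound 1 gives > 10000 nM, which is a limit of the assay and not a number. Compound 2 gives > 10000 nM in this assay, again a limit rather than a number. The step that the two limits leave unreadable from compound 1 to compound 2 cannot be read because both values sit at the limit of > 10000 nM in this assay, at which 2 of the 2 values shown sit.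

Compound 3 `c1ccc(-c2ccc(Cn3cncc3CNc3ccc(-c4ccc[nH]4)c(-c4ccccc4)c3)cc2)cc1` differs from compound 1 by 1H-pyrrol-2-yl in place of phenyl on an aromatic carbon. Going by the values given here, the only measured step, from compound 1 to compound 2, is unreadable, so no measured step gives a size to expect for this change; what is known of compound 1 is only its limit. The step that the limit leaves unreadable from compound 1 to compound 3 is therefore expected to stay within the scatter, with the result most likely again reported only as a limit. Compound 3 is estimated at 15000 nM in this assay, with a range from 5000 nM to 50000 nM.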

Compound 3, half-maximal effective concentration: > 10000 nM
Compound 3: no number, only a limit; the forecaster's own chance of this, stated with the estimate: 80%; the middle value lies beyond the limit too.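

The step from compound 1 to compound 3 cannot be read, since both compounds sit at a limit of the assay rather than at a number: the limit of > 10000 nM in this assay, at which 3 of the 3 values shown sit.

The compounds shown leave open how much of compound 1, compound 2 or compound 3 is needed for the effect in this assay and whether these changes alter that amount at all.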